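The source may report more compounds than this note shows. Statements on the series, on what has been measured and on what is new or still open speak of the compounds shown alone.

Working notes on the series. Compound 1 `Nc1cc(N)c2nc(-c3ccccc3)c(NCc3ccc(Cl)c(Cl)c3)nc2c1` is measured in a functional assay on MDA-MB-231 cells (Homo sapiens) for inhibition, read by sulforhodamine B assay, with a stated time of 48 h (a higher number here means a weaker inhibitor of growth, a lower number a stronger inhibitor of growth), at 4470 nM. It holds the lowest of the two numbers recorded so far; compound 2 `CCOC(=O)[C@H](CCC(=O)O)NC(=O)c1ccc(Oc2nc3cc(N)cc(N)c3nc2-c2ccccc2)cc1`, which carries a much larger substituent on the shared core, gives 32400 nM in this assay, a gap beyond the usual scatter. Among the measured compounds shown here, no pair of compounds that differ in a single place has been measured, so the effect of a change at the benzylic position is not yet known from data.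

Compound 3 `COc1ccc(CNc2nc3cc(N)cc(N)c3nc2-c2ccccc2)cc1` differs from compound 1 by one exchange: 4-methoxyphenyl in place of 3,4-dichlorophenyl on a saturated chain carbon bound to a nitrogen on an aromatic ring. For the measured compounds named here, with no measured step to rest on, a modest shift in this assay is expected, more likely toward a higher number than a lower one, and possibly not beyond the scatter. The step from compound 1 to compound 3 is estimated at a 1.8-fold higher number from compound 1 to compound 3 (0.25 log units; within the scatter). For compound 3 the expected value in this assay is 8000 nM, with a range from 2500 nM to 25000 nM.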

Compound 3, concentration for total growth inhibition: 13800 nM
Compound 3: the middle estimate sits 1.7-fold (0.24 log units) below what was measured; the measured number falls inside the stated range.
By their numbers in this assay, from the lowest: compound 1; then compound 3; then compound 2.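

In this assay, among the compounds shown here, the exchange of 3,4-dichlorophenyl for 4-methoxyphenyl on a saturated chain carbon bound to a nitrogen on an aromatic ring gives a 3.1-fold higher number from compound 1 to compound 3 (0.49 log units; beyond the scatter), the first single-place reading for this series. It shows that the number responds to this exchange at this position, with the shared core unchanged. Both groups hold one six-membered aromatic ring of carbon only, so the step arises with the ring kept and its substituents exchanged, and nothing at hand accounts for its size.

A single pair cannot divide the step between the departure of the two chlorine atoms and the arrival of the methoxy group. Also open, on these data alone, is how an unsubstituted phenyl, a 4-chlorophenyl or a pyridyl ring would read at this place.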